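A few compounds are considered here, and "the series" means these few. Any claim that something is new, unique, unknown or untested is made for them only; others in the source may bear on it.

Of the compounds shown here, three have so far been measured in a functional assay on Malme-3M cells (Homo sapiens) for cytotoxicity, read by sulforhodamine B assay, with a stated time of 48 h, tested at 100 nM; a lower number here means a stronger effect, a higher number a weaker effect of the compound at the concentration tested. Compound 1 `COc1cc(C)cc(-c2c(-c3ccnc(-c4ccc(C(C)=O)cc4)c3)cnn2CC#N)c1` gives 97% in this assay, and compound 2 `Cc1cc(O)cc(-c2nn(CC#N)cc2-c2ccnc(-c3ccc(Oc4ccccc4)cc3)c2)c1` gives 93%. Compound 3 `COc1cc(C)cc(-c2nn(CC#N)cc2-c2ccnc(-c3ccc(N(C)C)cc3)c2)c1` gives 46% in this assay, the lowest of the three numbers: it stands beyond the scatter below compound 2, its nearest neighbour, and further still beyond the scatter below compound 1. Within this small set compound 3 therefore shows the strongest effect.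

Compound 4 `Cc1cc(O)cc(-c2nn(CC#N)cc2-c2ccnc(-c3ccc(N(C)C)cc3)c2)c1` has not yet been measured. It differs from compound 3 by hydrogen in place of methyl on an oxygen on an aromatic ring. The difference is a single carbon leaving, with no ring and no donor or acceptor counted among what leaves.

Within the data shown here, no pair of measured compounds isolates this change. Compound 2 carries the hydroxy form of the same ring, but it differs from compound 3 elsewhere as well, so its value and that of compound 3 cannot be read as one step. With only that to go on, the step from compound 3 to compound 4 in this assay is expected to be modest, a number 12 percentage points higher from compound 3 to compound 4 (beyond the scatter), leaning towards a weaker effect but possibly within the scatter. Compound 4 is accordingly estimated at 58%, with a range from 35% to 85%.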

Compound 4, a percentage reported as activity, at one concentration (the size of the read-out at that concentration, not a potency): 94%
The estimate for compound 4 lay 36 percentage points below the measured number, outside the stated range (above it).
By their numbers in this assay, from the lowest: compound 3; then compounds 2, 4 and 1 (each within the scatter of the next).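

In this assay, among these compounds, methoxy to hydroxy on the 3-methoxy-5-methylphenyl group, with the dimethylamino group held in place, gives a number 48 percentage points higher from compound 3 to compound 4 (beyond the scatter) and is the first single change in this set that can be read on its own; it shows that this oxygen position is not indifferent, since the loss of one methyl is enough to take away most of the effect seen at the concentration tested. With the hydroxy form held in place, dimethylamino in place of phenoxy gives a number 1 percentage points higher from compound 2 to compound 4 (within the scatter) and so lies within the scatter, which means that the two groups cannot be told apart on this hydroxy background in this assay. No measurement shown here gives a reason for the large step.

The compounds shown leave open whether a longer chain on the same oxygen, such as ethoxy, or an amino group in place of the methoxy would keep the effect of compound 3. They also leave open whether phenoxy and dimethylamino would still lie within the scatter of each other on the methoxy background.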